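The source may report more compounds than this note shows. Statements on the series, on what has been measured and on what is new or still open speak of the compounds shown alone.

Compound 1 `CCn1cc(-c2nc3ccc([N+](=O)[O-])cc3[nH]2)c(=O)c2cc(F)c(N3CCNCC3)cc21` and compound 2 `CCn1cc(-c2nc3ccc([N+](=O)[O-])cc3[nH]2)c(=O)c2cc(F)c(N3CCNCC3)nc21` both carry the nitro group; the difference between their two cores is not broken down here. In a functional assay on KB cells (Homo sapiens) for cytotoxicity, read by MTT assay, with a stated time of 48 h (a lower number here means a stronger inhibitor, a higher number a weaker inhibitor), compound 1 gives 1100 nM, while in this assay compound 2 gives 22400 nM, so the two cores already stand well apart. Compound 3 `CCn1cc(-c2nc3ccc(N)cc3[nH]2)c(=O)c2cc(F)c(N3CCNCC3)cc21` is compound 1 with amino in place of nitro on an aromatic carbon; in this assay compound 3 gives 35400 nM, a step of a 32-fold higher number from compound 1 to compound 3 (1.51 log units; beyond the scatter). Compound 4 `CCn1cc(-c2nc3ccc(N)cc3[nH]2)c(=O)c2cc(F)c(N3CCNCC3)nc21` is compound 2 with amino in place of nitro on an aromatic carbon. The two place descriptions agree word for word, so this is the same change, seen once in measured form. Because that single measured step a 32-fold higher number from compound 1 to compound 3 (1.51 log units; beyond the scatter) is large and beyond the scatter, a step of similar size is expected from compound 2 to compound 4 in this assay, roughly an 8.9-fold higher number from compound 2 to compound 4 (0.95 log units; beyond the scatter). For compound 4 the estimate in this assay is 200000 nM, with a range from 50000 nM to 800000 nM, and a real chance that only a limit is reported.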

Compound 4, half-maximal inhibitory concentration: 30100 nM
For compound 4 the middle estimate is 6.6-fold (0.82 log units) above the measured one, outside the stated range (below it).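

In this assay, amino in place of nitro on an aromatic carbon gives a 1.3-fold higher number from compound 2 to compound 4 (0.13 log units; within the scatter), which leaves the pair indistinguishable here. The size of this step depends on the core, and the step read on one core does not carry over to the other: the same change on two cores in this assay, a 32-fold higher number (1.51 log units; beyond the scatter) from compound 1 to compound 3 and a 1.3-fold higher number (0.13 log units; within the scatter) from compound 2 to compound 4, 24-fold (1.38 log units) apart, beyond the scatter of two such steps

With a single pair on each core, this shows that the two cores respond differently, but not why, nor how a further core would respond. The compounds shown carry only nitro or amino at this place, so it stays open whether another group there, such as a nitrile or a carboxylic acid, would also give steps that differ between the two cores.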